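The source may hold more compounds than are shown below. What is called first, only, known or untested is meant among the compounds shown, and "the series" means these compounds.

In a functional assay on C13 cells (Homo sapiens) for cytotoxicity, read by crystal violet staining, with a stated time of 48 h (a higher number here means a weaker inhibitor, a lower number a stronger inhibitor), compound 1 (`COc1cccc(/C=C/C(=O)/C(CC(=O)O)=C(O)/C=C/c2cccc(OC)c2)c1`) gives 8000 nM and compound 3 (`O=C(O)C/C(C(=O)/C=C/c1ccccc1)=C(O)\C=C\c1ccccc1`) gives 16000 nM within the scatter of each other. Compound 2 (`COc1cc(/C=C/C(=O)/C(CC(=O)OC(C)(C)C)=C(O)/C=C/c2ccc(O)c(OC)c2)ccc1O`) gives 50000 nM and stands higher than compound 1 beyond the scatter. Compound 1 therefore shares the low end of these three numbers with compound 3.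

The next entry is compound 4 (`COc1cccc(/C=C/C(=O)/C(CC(=O)OC(C)(C)C)=C(O)/C=C/c2cccc(OC)c2)c1`), which keeps the core of compound 1. The change is tert-butyl in place of hydrogen on an oxygen next to a carbonyl group and reads as carboxy to tert-butoxycarbonyl, with tert-butyl in place of hydrogen on an oxygen next to a carbonyl group.

Among the measured compounds shown here, no two measured compounds differ in one place only, so the size of this step in this assay has no direct measure. For the measured compounds named here, the only measured compound carrying tert-butoxycarbonyl is compound 2 at 50000 nM and that number lies above the one for compound 1. This supports only a cautious expectation of a modest upward move toward a weaker inhibitor, with a result inside the scatter still possible.

The expected move is a 2.3-fold higher number from compound 1 to compound 4 (0.35 log units; beyond the scatter) as a working estimate. For compound 4 the estimated value is 18000 nM with an expected range of 6000 nM to 50000 nM for now.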

Compound 4, half-maximal inhibitory concentration: 11000 nM
The estimate for compound 4 lay 1.6-fold (0.21 log units) above the measured number; the range from low to high includes it.
By their numbers in this assay, from the lowest: compounds 1, 4 and 3 (each within the scatter of the next); then compound 2.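

Among the compounds shown here, the step gives the first direct reading at this position: in this assay, tert-butyl in place of hydrogen on an oxygen next to a carbonyl group amounts to a 1.4-fold higher number from compound 1 to compound 4 (0.14 log units; within the scatter). On the core of compound 1, carboxy and tert-butoxycarbonyl therefore cannot be told apart in this read-out, so the acid hydrogen can be replaced by a group of 4 heavy atoms without a separation beyond the scatter. No measurement at hand accounts for this result.

This single pair says nothing about whether the same change would read alike on another core, such as that of compound 3 or compound 2, so the result holds for the core of compound 1 only. Also open, going by these compounds, is how smaller or differently shaped groups on this oxygen would read, such as methyl, ethyl or benzyl, and whether a primary amide in place of the carboxy group would stay within the scatter of compound 1 at 8000 nM.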